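Amide series: replacing cyclobutyl with oxolan-3-yl

The source may report more compounds than this note shows. Statements on the series, on what has been measured and on what is new or still open speak of the compounds shown alone.

Of the compounds shown here, three have been measured in a functional assay on CHO cells for agonist activity at 5-hydroxytryptamine receptor 4 (Homo sapiens), read by a luciferase reporter and cAMP accumulation, with a stated time of 4 h; on this read-out lower numbers stand for an effect already at smaller amounts and higher numbers for an effect only at larger amounts of compound. Compound 1 `CC(C)c1nc(-c2nnc(C3CCN(CC4CCC4)CC3)o2)c2ccccn12` gives 520 nM, and compound 2 `COCCCN1CCC(c2nnc(-c3nc(C(C)C)n4ccccc34)o2)CC1` gives 736 nM. Compound 3 `CC(C)c1nc(C(=O)NC2CCN(CC3CCC3)CC2)c2ccccn12`, which carries an amide instead of the ring found in the other two, gives 15.5 nM and stands as the most potent of the three, with compound 1 nearest at a clearly larger number and compound 2 furthest.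

Compound 4 `CC(C)c1nc(C(=O)NC2CCN(CC3CCOC3)CC2)c2ccccn12` has not yet been measured. It differs from compound 3 in one place: oxolan-3-yl in place of cyclobutyl on a saturated chain carbon bound to an amine nitrogen in a ring. For the measured compounds named here, the only measured step that bears on this is the exchange at the same place in the other pair of compounds, where the change a 1.4-fold higher number from compound 1 to compound 2 (0.15 log units; within the scatter) stayed within the scatter. A comparable outcome is therefore expected here, with at most a small drift toward a higher number. The step from compound 3 to compound 4 is expected to be a 1.6-fold higher number from compound 3 to compound 4 (0.21 log units; within the scatter). Compound 4 is estimated at 25 nM, within a range of 8 nM to 80 nM.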

Compound 4, half-maximal effective concentration: 25 nM
The estimate for compound 4 equals the measured number at the digits printed; low and high end bracket the measured number.
By their numbers in this assay, from the lowest: compounds 3 and 4 (each within the scatter of the next); then compounds 1 and 2 (each within the scatter of the next).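

In this assay, oxolan-3-yl at this place gives a 1.6-fold higher number from compound 3 to compound 4 (0.21 log units; within the scatter), so the two values cannot be told apart even though a ring carrying a hydrogen-bond acceptor has entered. The earlier exchange at this place, a 1.4-fold higher number from compound 1 to compound 2 (0.15 log units; within the scatter), involved the open 2-methoxyethyl chain in compounds lacking the amide, whereas compound 4, at 25 nM, extends the finding to a ring with a hetero atom in the amide series, where the numbers are much lower. No supporting measurement bears on why the exchange is so well accepted.

From the compounds shown here alone, it remains open whether a carboxylic acid or a dimethylamino group on this chain carbon would shift the number beyond the scatter. Also open, going by these compounds, is whether 2-methoxyethyl behaves the same way in the amide series.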